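Fluoro on the fused ring: from compound 3 to compound 4

The source may report more compounds than this note shows. Statements on the series, on what has been measured and on what is new or still open speak of the compounds shown alone.

Measured in an assay on membranes from frontal cortex for displacement of a labelled ligand from Adrenergic receptor alpha-1 (Rattus norvegicus), read by scintillation counting, with a stated time of 45 min; on this read-out lower numbers stand for stronger inhibition and higher numbers for weaker inhibition:
- compound 1 `CCC1(CCCCN2CCN(c3ccccc3Cl)CC2)C(=O)Nc2ccccc21` gives 64 nM
- compound 2 `CCC1(CCCCN2CCN(c3cccc(Cl)c3)CC2)C(=O)Nc2ccccc21` gives 31 nM
- compound 3 `O=C1Nc2ccccc2C1CCCCN1CCN(c2cccc(Cl)c2)CC1` gives 26 nM

Compound 3 shows the lowest number of the three, though compound 2 sits within the scatter of it; only compound 1 stands clearly apart, as the step of a 2.1-fold lower number from compound 1 to compound 2 (0.31 log units; beyond the scatter) and the step of a 1.2-fold lower number from compound 2 to compound 3 (0.08 log units; within the scatter) show. Compound 4 `O=C1Nc2cc(F)ccc2C1CCCCN1CCN(c2cccc(Cl)c2)CC1` differs from compound 3 by fluoro in place of hydrogen on an aromatic carbon, on the six-membered aromatic ring of the fused two-ring system. Neither measured step touches that ring: one moves a chloro group on the other aromatic ring, the other removes an ethyl from a saturated carbon. Among the measured compounds shown here, no step therefore bears directly on this change, and a change no larger than the scatter is expected, a 1.0-fold lower number from compound 3 to compound 4 (0.02 log units; within the scatter). Compound 4 is estimated at 25 nM, between 10 nM and 60 nM.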

Compound 4, inhibition constant: 12.5 nM
For compound 4 the middle estimate is 2.0-fold (0.30 log units) above the measured one; measured number inside the range.
By their numbers in this assay, from the lowest: compound 4; then compounds 3 and 2 (each within the scatter of the next); then compound 1.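

In this assay, fluoro in place of hydrogen on the six-membered aromatic ring of the fused system gives a 2.1-fold lower number from compound 3 to compound 4 (0.32 log units; beyond the scatter), a modest step. This shows that a change of a single atom on this ring can move the number beyond the scatter. Neither earlier step touched this ring, so neither could show this. No measurement shown here explains the shift. On these data alone, whether this step is particular to fluoro remains open: chloro, methoxy or an amine on the same carbon could answer that. Fluoro on another carbon of this ring would show whether the position matters.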